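Swapping a chlorophenyl ring for isopropyl on a fused core

A few compounds are considered here, and "the series" means these few. Any claim that something is new, unique, unknown or untested is made for them only; others in the source may bear on it.

Of the compounds shown here, two have been tested in a functional assay on BeWo cells (Homo sapiens) for cytotoxicity, read by MTT assay, with a stated time of 72 h (on this read-out higher numbers stand for weaker inhibition and lower numbers for stronger inhibition), so far. Compound 1, with the structure `Clc1ccccc1-c1nnc2nnc(N3CCCC3)nn12`, gives 2990 nM in this assay. Compound 2, with the structure `Fc1ccc(-c2nnc3nnc(N4CCCCC4)nn23)cc1`, gives 3340 nM in this assay. The two numbers lie within the usual scatter of each other, so neither compound can be called stronger or weaker than the other on this evidence.

Compound 3, with the structure `CC(C)c1nnc2nnc(N3CCCC3)nn12`, has not yet been measured. It differs from compound 1 in one place: isopropyl in place of 2-chlorophenyl on an aromatic carbon. The 2-chlorophenyl group sits on an aromatic carbon of a five-membered aromatic ring, and the isopropyl group takes its place there.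

Going by the values given here, no measured pair shows what such a swap does in this assay, so the direction of the step is open. A modest weakening is expected, with the step from compound 1 to compound 3 estimated at a 1.7-fold higher number from compound 1 to compound 3 (0.22 log units; within the scatter). Compound 3 is therefore expected to give about 5000 nM in this assay, with a likely range from 1500 nM to 20000 nM.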

Compound 3, half-maximal inhibitory concentration: 3430 nM
Beside the measured number, compound 3's estimate is 1.5-fold (0.16 log units) above it, and the stated range covers the measured number.
By their numbers in this assay, from the lowest: compounds 1, 2 and 3 (each within the scatter of the next).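

In this assay, placing isopropyl where compound 1 carries 2-chlorophenyl, on the aromatic carbon of the five-membered aromatic ring, gives a 1.1-fold higher number from compound 1 to compound 3 (0.06 log units; within the scatter). Going by these compounds alone, this pair is the first direct look at a change at this position, since compound 1 and compound 2 differ in more than one place and could not show what one swap does. Here a group of 7 heavy atoms with a six-membered aromatic ring gives way to one of 3 heavy atoms with no ring, and the number stays within the usual scatter, so for this pair the aromatic ring is not required for activity in this range, though no measurement on hand explains that result.

On these data alone, one pair cannot show how far this tolerance extends, and whether a carboxylic acid, an amine or a longer alkyl chain on the same carbon would leave the number in place remains open. As far as these compounds go, it also remains open whether the same swap would behave alike on a compound with a different ring amine on the shared core, such as the piperidine of compound 2.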